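The compounds below may be only part of what the source reports. "The series", "measured", "known", "first", "only" and "open" are said of these compounds alone.

Working notes on the series in a functional assay on HCT-116 cells (Homo sapiens) for antiproliferative activity, read by sulforhodamine B assay, with a stated time of 72 h; on this read-out lower numbers stand for stronger inhibition and higher numbers for weaker inhibition.

Three compounds carry the shared core with different groups on the chain that leaves the saturated ring carbon. Compound 1 `Cn1ncc(Cl)c1-c1cc(C(=O)N[C@@H]2CN[C@H](CCn3cncn3)C[C@H]2c2ccc(Cl)c(Cl)c2)oc1Cl` gives 560 nM. Compound 2 `Cn1ncc(Cl)c1-c1cc(C(=O)N[C@@H]2CN[C@H](CCO)C[C@H]2c2ccc(Cl)c(Cl)c2)oc1Cl` gives 340 nM. Compound 3 `Cn1ncc(Cl)c1-c1cc(C(=O)N[C@@H]2CN[C@H](CC(=O)NCCO)C[C@H]2c2ccc(Cl)c(Cl)c2)oc1Cl` gives 670 nM; this is the highest number of the three, yet the step of a 1.2-fold higher number from compound 1 to compound 3 (0.08 log units; within the scatter) and the step of a 2.0-fold higher number from compound 2 to compound 3 (0.29 log units; within the scatter) are both within the scatter, as is a 1.6-fold lower number from compound 1 to compound 2 (0.22 log units; within the scatter). On the numbers shown, the three chain groups are not separable.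

Compound 4 `CCC[C@@H]1C[C@@H](c2ccc(Cl)c(Cl)c2)[C@H](NC(=O)c2cc(-c3c(Cl)cnn3C)c(Cl)o2)CN1` continues this line: ethyl in place of (2-hydroxyethyl)carbamoyl on a saturated chain carbon bound to a saturated ring carbon. All three measured steps bear on it, since each exchanges the group on the same saturated chain carbon, and none of them moved the read-out beyond the scatter. For the measured compounds named here, no measured pair shows what removal of every donor and acceptor from the chain does, so the expectation rests on the tolerance seen so far. For compound 4 the expected step from compound 3 is a 1.3-fold lower number from compound 3 to compound 4 (0.13 log units; within the scatter), with no movement beyond the scatter. Compound 4 is thus estimated at 500 nM, in the range 170 nM to 1500 nM.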

Compound 4, half-maximal inhibitory concentration: 1020 nM
Compound 4: the middle estimate sits 2.0-fold (0.31 log units) below what was measured; the measured number falls inside the stated range.
By their numbers in this assay, from the lowest: compounds 2, 1, 3 and 4 (each within the scatter of the next, the first and the last beyond it).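

In this assay, for the compounds shown here, compound 4 gives the first step at this position to lie beyond the scatter: a 3.0-fold higher number from compound 2 to compound 4 (0.48 log units; beyond the scatter), with methyl in place of hydroxy on a saturated chain carbon, two bonds along the chain from a saturated ring carbon. The other two steps, a 1.5-fold higher number from compound 3 to compound 4 (0.18 log units; within the scatter) and a 1.8-fold higher number from compound 1 to compound 4 (0.26 log units; within the scatter), remain within the scatter, so the chain groups separate only at the two ends of the series and give no order among all four compounds. Nothing available explains the difference between the hydroxy and methyl chain ends.

On these data alone, whether the hydroxy itself matters remains open, and a methoxy on the same saturated chain carbon would bear on that. Also open, as far as these compounds go, are the effects of an amine, a carboxylic acid or a chain longer than propyl.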